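Working notes: methyl on the amine nitrogen of compound 2

The source may report more compounds than this note shows. Statements on the series, on what has been measured and on what is new or still open speak of the compounds shown alone.

Compound 2, `N#Cc1ccc(Nc2cnccc2SCCCCCCC(=O)O)c2ccccc12`, stands highest of the three measured compounds in an assay on HEK293 cells for inhibition of solute carrier family 22 member 12 (Homo sapiens), read by scintillation counting, with stated times of 30 min and 15 min (a higher number here means a weaker inhibitor, a lower number a stronger inhibitor), at 5750 nM. Compound 3, `N#Cc1ccc(Nc2cnccc2SCCCCC(=O)O)c2ccccc12`, gives 2280 nM in this assay, and compound 1, `N#Cc1ccc(Nc2cnccc2SCc2ccccc2C(=O)O)c2ccccc12`, gives 240 nM. Every measured step concerns the group on the saturated chain carbon bound to the sulfur: a 24-fold higher number from compound 1 to compound 2 (1.38 log units; beyond the scatter), a 9.5-fold higher number from compound 1 to compound 3 (0.98 log units; beyond the scatter) and a 2.5-fold lower number from compound 2 to compound 3 (0.40 log units; beyond the scatter). Compound 2 thus sits at the weak end of the series as measured so far.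

Compound 4, `CN(c1cnccc1SCCCCCCC(=O)O)c1ccc(C#N)c2ccccc12`, differs from compound 2 in one place: methyl in place of hydrogen on a nitrogen on an aromatic ring. None of the three measured steps touches this nitrogen; each of them alters the acid-bearing chain and leaves the amine hydrogen in place. Among the measured compounds shown here, no measured step therefore bears on the change from compound 2 to compound 4, and neither its direction nor its size can be read from the series. The expectation is accordingly held close to compound 2 with a wide range, allowing for a modest movement in either direction beyond the scatter. Compound 4 is expected to give 8000 nM in this assay, within 2500 nM to 25000 nM. That estimate amounts to a 1.4-fold higher number from compound 2 to compound 4 (0.14 log units; within the scatter).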

Compound 4, half-maximal inhibitory concentration: 4640 nM
Estimate against measurement, compound 4: 1.7-fold (0.24 log units) above; measured number inside the range.
By their numbers in this assay, from the lowest: compound 1; then compound 3; then compounds 4 and 2 (each within the scatter of the next).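

In this assay, among the compounds shown here, methyl in place of hydrogen on a nitrogen on an aromatic ring gives a 1.2-fold lower number from compound 2 to compound 4 (0.09 log units; within the scatter), the only measured step at this nitrogen. Unlike the three steps on the acid-bearing chain, each printed as beyond the scatter, this one lies within it, so with the chain of compound 2 the hydrogen on this nitrogen can be exchanged for methyl with no measurable change in this assay. Nothing at hand offers a reason for this result, and no measured property bears on it.

The compounds shown leave open whether the same exchange would stay within the scatter on the 2-carboxyphenyl side chain of compound 1, which gives 240 nM, since the only reading at this nitrogen comes from a compound with a far higher number. They also leave open what a group larger than methyl on this nitrogen, such as an ethyl or an acetyl, would do, and whether the nitrogen tolerates anything beyond a single carbon.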